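This account rests on a few compounds, and the source may have more. Where it says the series, first, only, none or still open, it means among the compounds named here.

In an ADME assay on microsomes from liver (Homo sapiens) for metabolic stability, read by LC-MS, with a stated time of 30 min, tested at 1 uM (on this read-out higher numbers stand for a more stable compound and lower numbers for a less stable compound), compound 1 (`O=C(NCc1ccc(S(=O)(=O)c2ccccc2)cc1)c1cc2ccncc2s1`) gives 48% and compound 2 (`O=C(NCc1ccc(S(=O)(=O)c2ccccc2)cc1)c1cc2ncccc2s1`) gives 81% as the higher of the two numbers. Compound 3 (`O=C(NCc1ccc(S(=O)(=O)c2ccccc2)cc1)c1nc2ccncc2s1`) alters compound 2 on the carbonyl carbon (a group of 9 heavy atoms (6 carbon, 2 nitrogen, 1 sulfur; one five-membered aromatic ring with 2 hetero atoms, one six-membered aromatic ring with 1 hetero atom) in place of a group of 9 heavy atoms (7 carbon, 1 nitrogen, 1 sulfur; one five-membered aromatic ring with 1 hetero atom, one six-membered aromatic ring with 1 hetero atom), on a carbonyl carbon). Among the compounds with values here, the one measured step at that place (a number 33 percentage points higher from compound 1 to compound 2 (beyond the scatter)) was large, so a sizeable step is expected again. A fall is expected rather than a rise because compound 2 already stands at 81% on this read-out. The expected change is (a number 23 percentage points lower from compound 2 to compound 3 (beyond the scatter)). Compound 3 is estimated to give (58%), with an expected range (33% to 82%).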

Compound 3, percent of the compound remaining: 68%
Beside the measured number, compound 3's estimate is 10 percentage points below it; the range from low to high includes it.
By their numbers in this assay, from the lowest: compound 1; then compound 3; then compound 2.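

In this assay, the group on the carbonyl carbon with 2 hetero atoms in its five-membered aromatic ring gives two results: a number 13 percentage points lower from compound 2 to compound 3 (beyond the scatter), and a number 20 percentage points higher from compound 1 to compound 3 (beyond the scatter). This group therefore sits in the middle of the three, and the effect of the change depends on which group it replaces. Nothing available bears on the reason for this order. From the compounds shown here alone, it remains open how this read-out would respond to a methoxy group or an amine on the six-membered aromatic ring of the group at this position.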